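The compounds below may be only part of what the source reports. "The series", "measured", "known", "first", "only" and "open" are said of these compounds alone.

Compound 3 `COc1ccc2nc(-c3ccc(-n4c(C)ccc4-c4ccc(C)cc4)cc3)sc2c1` was tested in an ADME assay on MCF-10A cells (Homo sapiens) for cytotoxicity, read by MTT assay, with a stated time of 72 h (a lower number here means a stronger inhibitor, a higher number a weaker inhibitor), where compound 3 gives 34000 nM. Among the three compounds measured so far it returns the lowest number, yet its gaps to its neighbours lie within the scatter: compound 2 `Cc1ccc(-c2ccc(F)cc2)n1-c1ccc(-c2nc3ccc(F)cc3s2)cc1` gives 37800 nM, and compound 1 `Cc1ccc(-c2ccc(F)cc2)n1-c1ccc(-c2nc3ccccc3s2)cc1` gives 40000 nM. For the measured compounds named here, the one measured step, a 1.1-fold lower number from compound 1 to compound 2 (0.02 log units; within the scatter), likewise stays within the scatter.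

Compound 4 `COc1ccc2nc(-c3ccc(-n4c(C)ccc4-c4ccc(F)cc4)cc3)sc2c1` has not yet been measured. It differs from compound 3 in a single place: fluoro in place of methyl on an aromatic carbon, on an aromatic carbon of a six-membered aromatic ring of carbon only; cut one bond further out, the change reads 4-methylphenyl to 4-fluorophenyl. Going by the values given here, no measured step swaps fluoro for methyl, and the only step that touches a fluoro, from compound 1 to compound 2, changed the number hardly at all. The expectation for compound 4 is therefore a step of a 1.1-fold higher number from compound 3 to compound 4 (0.02 log units; within the scatter), none beyond the scatter. Compound 4 is estimated at 36000 nM, with a range from 18000 nM to 72000 nM.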

Compound 4, half-maximal inhibitory concentration: 38300 nM
Compound 4: middle estimate off by 1.1-fold (0.03 log units), on the low side; measured number inside the range.
By their numbers in this assay, from the lowest: compounds 3, 2, 4 and 1 (each within the scatter of the next).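

In this assay, for the compounds shown here, fluoro in place of methyl on the six-membered aromatic ring, para to a large group, gives a 1.1-fold higher number from compound 3 to compound 4 (0.05 log units; within the scatter), the first reading of this exchange at this place. The substituent on the shared core, earlier varied only from hydrogen to fluoro, now has a reading for methoxy as well: methoxy in place of fluoro gives a 1.0-fold higher number from compound 2 to compound 4 (0.01 log units; within the scatter), and methoxy in place of hydrogen gives a 1.0-fold lower number from compound 1 to compound 4 (0.02 log units; within the scatter). None of these changes, at either place, moves the number beyond the scatter.

No measurement offered here gives a cause for these readings. From the compounds shown here alone, whether an amine or a carboxylic acid in place of the fluoro of the 4-fluorophenyl group would shift the number beyond the scatter remains open.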